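This account rests on a few compounds, and the source may have more. Where it says the series, first, only, none or still open, it means among the compounds named here.

Series notes. Compound 1 `COc1ccc2[nH]c(-c3cccc(F)c3)cc(=O)c2c1OC` gives 3500 nM in a functional assay on NCI-H460 cells (Homo sapiens) for cytotoxicity, read by MTT assay, with a stated time of 48 h; on this read-out lower numbers stand for stronger inhibition and higher numbers for weaker inhibition. Compound 2 `COc1ccc2[nH]c(-c3ccc(F)cc3)cc(=O)c2c1OC` reaches only a limit of this assay, > 20000 nM. The step from compound 1 to compound 2 is an at least 5.7-fold higher number from compound 1 to compound 2 (0.75 log units; beyond the scatter), the change being (4-fluorophenyl in place of 3-fluorophenyl on an aromatic carbon); the end point of that step is a limit, (the limit of > 20000 nM in this assay, at which 1 of the 3 values shown sits), so only a lower bound of the step is known. Compound 3 `COc1cc2c(=O)cc(-c3cccc(F)c3)[nH]c2cc1O` gives 4800 nM in this assay; its value and that of compound 1 lie within the scatter of each other. The difference between the core of compound 3 and the core of compound 1 is not broken down here. Compound 4 `COc1cc2c(=O)cc(-c3ccc(F)cc3)[nH]c2cc1O` is not yet measured in this assay. It differs from compound 3 by 4-fluorophenyl in place of 3-fluorophenyl on an aromatic carbon, the same change as that from compound 1 to compound 2, at the same place. Since the step from compound 1 to compound 2 gave an at least 5.7-fold higher number from compound 1 to compound 2 (0.75 log units; beyond the scatter), a step of similar size is expected from compound 3 to compound 4 in this assay, a 5.2-fold higher number from compound 3 to compound 4 (0.72 log units; beyond the scatter). Compound 4 is estimated at 25000 nM, between 10000 nM and 70000 nM, with a fair chance that only a limit is reported.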

Compound 4, half-maximal inhibitory concentration: > 100000 nM
Compound 4 was reported as a limit; the forecaster's own chance of this, stated with the estimate: 65%; middle value at least 4.0-fold (0.60 log units) from the limit.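

In this assay, 4-fluorophenyl in place of 3-fluorophenyl gives an at least 20-fold higher number from compound 3 to compound 4 (1.31 log units; beyond the scatter), so the direction of the change carries over to the second core and the step lies beyond the scatter on both cores. Set side by side, the two steps read: the same change on two cores in this assay, an at least 5.7-fold higher number (0.75 log units; beyond the scatter) from compound 1 to compound 2 and an at least 20-fold higher number (1.31 log units; beyond the scatter) from compound 3 to compound 4; the limit leaves it open whether they differ Both end points are limits, so the true size of neither step is known, and nothing here shows that the change costs more on one core than on the other; two cores also make no general rule for the series.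

Going by these compounds, it remains open whether anything other than fluorine, such as an amine, a methoxy group or a carboxylic acid, would show the same dependence on place on this phenyl ring. Also open, on these data alone, are the actual values of compound 2 and compound 4, and whether the step would recur on a third core.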